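Ethyl in Place of Cyclohexyl on the Ring Nitrogen

The source may hold more compounds than are shown below. What is called first, only, known or untested is meant among the compounds shown, and "the series" means these compounds.

Of the compounds shown here, three sharing one core have been measured in a functional assay on the whole organism (strain BALB/c) for inhibition, with Mus musculus as the target, read by paw edema, with a stated time of 4 h, at a dose of 50 mg/kg by the oral route; on this read-out higher numbers stand for more inhibition at the one dose given (going by the name of the read-out) and lower numbers for less inhibition. Compound 1 `COc1ccc(Nc2nnc(-c3cc(-c4ccc(F)cc4F)ccc3O)o2)cc1` gives 35.3%. Compound 2 `CNc1nnc(-c2cc(-c3ccc(F)cc3F)ccc2O)o1` gives 41.4%. Compound 3 `Oc1ccc(-c2ccc(F)cc2F)cc1-c1nnc(NC2CCCCC2)o1` gives 23.8%, the lowest of the three numbers: the step of a number 11.5 percentage points lower from compound 1 to compound 3 (beyond the scatter) and the step of a number 17.6 percentage points lower from compound 2 to compound 3 (beyond the scatter) both lie beyond the scatter, whereas the step of a number 6.1 percentage points higher from compound 1 to compound 2 (within the scatter) does not.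

Compound 4 `CCNc1nnc(-c2cc(-c3ccc(F)cc3F)ccc2O)o1` has not yet been measured. It differs from compound 3 in one place: ethyl in place of cyclohexyl on a nitrogen on an aromatic ring. The measured step that bears most directly on this change is a number 17.6 percentage points lower from compound 2 to compound 3 (beyond the scatter), in which methyl was exchanged for cyclohexyl; compound 4 undoes that exchange part of the way, since ethyl, like methyl, carries no ring. Compound 4 is therefore expected to recover much of that loss, a rise of about a number 12.2 percentage points higher from compound 3 to compound 4 (beyond the scatter) in this assay. The estimate for compound 4 is 36%, with a range from 22% to 50%.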

Compound 4, a percentage reported as inhibition, in the whole organism at one dose (the size of the read-out at that dose, not a potency): 36.8%
Estimate against measurement, compound 4: 0.8 percentage points below, and the stated range covers the measured number.
By their numbers in this assay, from the lowest: compound 3; then compounds 1, 4 and 2 (each within the scatter of the next).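

In this assay the step of a number 13 percentage points higher from compound 3 to compound 4 (beyond the scatter) shows that the gap to cyclohexyl on this nitrogen is not peculiar to methyl, since a second open chain, ethyl, also stands clear of it. Ethyl cannot be told apart from methyl, with a number 4.6 percentage points lower from compound 2 to compound 4 (within the scatter), or from 4-methoxyphenyl, with a number 1.5 percentage points higher from compound 1 to compound 4 (within the scatter), so among these four groups cyclohexyl alone stands apart, at the low end. Nothing measured here gives a reason for this.

The compounds shown leave open whether a longer chain such as butyl, or a branched one such as isopropyl, stays level with ethyl or falls toward cyclohexyl. They also leave open whether a smaller ring such as cyclopropyl, or the unsubstituted amine, does the same.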